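The source may report more compounds than this note shows. Statements on the series, on what has been measured and on what is new or still open speak of the compounds shown alone.

Compounds measured so far in a functional assay on MCF7 cells (Homo sapiens) for antiproliferative activity, read by MTT assay, with a stated time of 48 h; a lower number here means a stronger inhibitor, a higher number a weaker inhibitor:
- Compound 1 `Oc1ccc2ccccc2c1C(Nc1nc2ccc(Cl)cc2s1)c1cn(-c2ccccc2)nc1-c1ccc(F)cc1`: 21600 nM
- Compound 2 `COc1cccc(-c2nn(-c3ccccc3)cc2C(Nc2nc3ccc(Cl)cc3s2)c2c(O)ccc3ccccc23)c1`: 36000 nM
- Compound 3 `Oc1ccc2ccccc2c1C(Nc1nc2ccc(Cl)cc2s1)c1cn(-c2ccccc2)nc1-c1ccccc1`: 36300 nM

Compound 3 sits level with the other two, as its gaps to them lie within the usual scatter of such measurements: a 1.7-fold higher number from compound 1 to compound 3 (0.23 log units; within the scatter) and a 1.0-fold higher number from compound 2 to compound 3 (0.00 log units; within the scatter). Compound 4 `O=[N+]([O-])c1ccc(-c2nn(-c3ccccc3)cc2C(Nc2nc3ccc(Cl)cc3s2)c2c(O)ccc3ccccc23)cc1` differs from compound 3 in one place, with nitro in place of hydrogen on an aromatic carbon, para to a large group (nitro in place of hydrogen on an aromatic carbon).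

Within the data shown here, no measured compound carries a nitro group, so the guidance is indirect. The two steps above show that hydrogen, fluoro and methoxy variants give values within the scatter of one another, and so does a 1.7-fold higher number from compound 1 to compound 2 (0.22 log units; within the scatter). On these three compounds alone, no step beyond the scatter is expected in this assay, and no direction can be favoured with confidence. The expected step is a 1.3-fold lower number from compound 3 to compound 4 (0.10 log units; within the scatter). For compound 4 the estimated value is 29000 nM, with an expected range from 12000 nM to 65000 nM.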

Compound 4, half-maximal inhibitory concentration: 38600 nM
For compound 4 the middle estimate is 1.3-fold (0.12 log units) below the measured one; the range from low to high includes it.
By their numbers in this assay, from the lowest: compounds 1, 2, 3 and 4 (each within the scatter of the next).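

In this assay the change from phenyl to 4-nitrophenyl gives a 1.1-fold higher number from compound 3 to compound 4 (0.03 log units; within the scatter), so this ring position accepts a nitro group, with its three heavy atoms, without any step beyond the scatter. The other two comparisons agree, with a 1.1-fold higher number from compound 2 to compound 4 (0.03 log units; within the scatter) and a 1.8-fold higher number from compound 1 to compound 4 (0.25 log units; within the scatter), which extends the level picture seen with hydrogen, fluoro and methoxy to a fourth, quite different substituent. No measurement available here explains why the values stay level.

On these data alone, whether an amine or a carboxylic acid on this ring would produce a step beyond the scatter remains open. So does the effect of changes elsewhere, since all four compounds share the same core.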